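This account rests on a few compounds, and the source may have more. Where it says the series, first, only, none or still open, it means among the compounds named here.

Compound 1 `CCOC(=O)c1ccc(-n2ncc3cc(C)c(C(=O)OCC)c(C)c3c2=O)cc1` in a functional assay (plasma) for inhibition, with Oryctolagus cuniculus as the target (on this read-out higher numbers stand for an effect only at larger amounts of compound and lower numbers for an effect already at smaller amounts), gives >= 50 uM, which is a limit of the assay.
Compound 2 `CCOC(=O)c1c(C)cc2cnn(-c3ccc(S(C)(=O)=O)cc3)c(=O)c2c1C` in this assay gives >= 50 uM, again a limit.
Compound 3 `CCOC(=O)c1c(C)cc2cnn(-c3ccc([N+](=O)[O-])cc3)c(=O)c2c1C` in this assay gives >= 50 uM, also a limit.

Compound 3 thus sits at the limit, where (the limit of >= 50 uM in this assay, at which 3 of the 3 values shown sit). The change to compound 4 `CCOC(=O)c1c(C)cc2cnn(-c3ccc(NC(C)=O)cc3)c(=O)c2c1C` is acetamido in place of nitro on an aromatic carbon. Within the data shown here, three measured steps concern a substituent on an aromatic carbon: a step that the two limits leave unreadable from compound 1 to compound 2, a step that the two limits leave unreadable from compound 1 to compound 3 and a step that the two limits leave unreadable from compound 2 to compound 3; none of them has a readable size. Nothing among them speaks for a step beyond the scatter, and the expectation is that compound 4 likewise remains at the limit, so the expected step is a number no higher from compound 3 to compound 4 (the limit leaves the size open). The estimate for compound 4 in this assay is 50 uM, with a range from 20 uM to 200 uM.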

Compound 4, concentration for half-maximal effect: >= 50 uM
Compound 4 ended at the assay's limit (the forecaster's own chance of this, stated with the estimate: 80%); the middle value lies on the limit itself.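

Among these compounds, compound 4 also sits at a limit, so no step among compound 1, compound 2, compound 3 and compound 4 can be read: the limit of >= 50 uM in this assay, at which 4 of the 4 values shown sit.

In this assay the compounds shown leave open whether any substituent at this aromatic carbon gives an effect at smaller amounts.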